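Ring-nitrogen substituents in a weak antiproliferative series

The source may report more compounds than this note shows. Statements on the series, on what has been measured and on what is new or still open speak of the compounds shown alone.

In a functional assay on A549 cells (Homo sapiens) for antiproliferative activity, read by MTT assay, with a stated time of 72 h (a higher number here means a weaker inhibitor, a lower number a stronger inhibitor), compound 3 `COc1ccc(N2C(=O)COc3ccc(-c4cccc(NS(=O)(=O)c5ccc(F)cc5)c4)cc32)cc1` gives 38200 nM and lies within the scatter of compound 1 `CC(C)N1C(=O)COc2ccc(-c3cccc(NS(=O)(=O)c4ccc(F)cc4)c3)cc21` at 29400 nM in the same read-out. Compound 2 `O=C1COc2ccc(-c3cccc(NS(=O)(=O)c4ccc(F)cc4)c3)cc2N1C1CC1` reads > 40000 nM as a limit of the assay and not a number. Compound 4 `O=C1COc2ccc(-c3cccc(NS(=O)(=O)c4ccc(F)cc4)c3)cc2N1C1CCCCC1` carries cyclohexyl in place of 4-methoxyphenyl on an amide-type nitrogen in a ring and so changes the one place varied among the measured compounds. The steps at that place bear on it: a 1.3-fold higher number from compound 1 to compound 3 (0.11 log units; within the scatter) and an at least 1.3-fold higher number from compound 1 to compound 2 (0.13 log units; that floor lies within the scatter) and an at least 1.0-fold lower number from compound 2 to compound 3 (0.01 log units; that floor lies within the scatter) all stay within the scatter. No step beyond the scatter is therefore expected in this assay and no direction is favoured. The estimated change is a 1.2-fold lower number from compound 3 to compound 4 (0.06 log units; within the scatter) as the expected outcome. The estimate for compound 4 is 33000 nM with an expected range of 15000 nM to 55000 nM in this read-out.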

Compound 4, half-maximal inhibitory concentration: 14500 nM
Compound 4: the middle estimate sits 2.3-fold (0.36 log units) above what was measured; measured number outside the range, below it.
By their numbers in this assay, from the lowest: compound 4; then compounds 1 and 3 (each within the scatter of the next). At a limit, above all of these: compound 2.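

Among these compounds, the nitrogen substituent is not silent in this assay: cyclohexyl gives the first steps at this place beyond the scatter, a 2.6-fold lower number from compound 3 to compound 4 (0.42 log units; beyond the scatter) and a 2.0-fold lower number from compound 1 to compound 4 (0.31 log units; beyond the scatter). Compound 2 stands at a limit of the assay and not a number: the limit of > 40000 nM in this assay, at which 1 of the 4 values shown sits. Against that limit the step is only a floor, an at least 2.7-fold lower number from compound 2 to compound 4 (0.44 log units; beyond the scatter).

The change from 4-methoxyphenyl to cyclohexyl removes both the aromatic ring and the methoxy oxygen, so the compounds shown do not separate the two. Unsubstituted phenyl, cyclopentyl and a piperidine ring remain open at this nitrogen.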